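This account rests on a few compounds, and the source may have more. Where it says the series, first, only, none or still open, it means among the compounds named here.

Measured compounds:
compound 1 `COC(=O)c1ccc(/C=N/Nc2ncnc3sc(C(C)(C)C)cc23)cc1` — "not determined" (no result reported) in a functional assay on PC-6 cells (Homo sapiens) for cytotoxicity, read by MTT assay, with a stated time of 3 days; a lower number here means a stronger inhibitor, a higher number a weaker inhibitor
compound 2 `CC(C)(C)c1cc2c(N/N=C/c3ccc4c(c3)CNCC4)ncnc2s1` — 0.069 ug/mL
compound 3 `CC(C)(C)c1cc2c(N/N=C/c3ccc4c(c3)CNC4)ncnc2s1` — 0.071 ug/mL

Compound 1 has no place on the numbers: in this assay nothing was reported for it, so it gives no anchor. Compounds 2 and 3 share the core and give values in this assay that lie within the scatter of each other. Compound 4 `CC(C)(C)c1cc2c(N/N=C/c3ccc(CO)cc3)ncnc2s1` is reached from compound 1 by the change (hydroxymethyl in place of methoxycarbonyl on an aromatic carbon). Going by the values given here, no measured step covers this change, and compound 1 carries no number, so no direction for the step in this assay can be read from the data; the only guide is that compounds 2 and 3 sit close together on the same core. Compound 4 is expected to give about 0.15 ug/mL in this assay, with an estimated range from 0.03 ug/mL to 0.8 ug/mL.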

Compound 4, half-maximal inhibitory concentration: 0.556 ug/mL
For compound 4 the middle estimate is 3.7-fold (0.57 log units) below the measured one; the measured number falls inside the stated range.
By their numbers in this assay, from the lowest: compounds 2 and 3 (each within the scatter of the next); then compound 4.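

Compound 4 gives no readable step from compound 1, which has no number in this assay. As far as these compounds go, the effect of hydroxymethyl in place of methoxycarbonyl stays open, and no supporting data bear on the value of compound 4.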